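A few compounds are considered here, and "the series" means these few. Any claim that something is new, unique, unknown or untested is made for them only; others in the source may bear on it.

Working notes on the series.

Three compounds of the shared core have numbers in an assay on isolated protein for inhibition of Aromatase (Homo sapiens), read by fluorescence; a higher number here means a weaker inhibitor, a lower number a stronger inhibitor. Compound 1 `COc1ccc(S(=O)(=O)N2CCCC(Cn3ccnc3)C2)cc1F` gives 14 nM. Compound 2 `COc1ccc(S(=O)(=O)N2CCCC(Cn3ccnc3)C2)c(OC)c1` gives 131 nM. Compound 3 `N#Cc1ccc(S(=O)(=O)N2CCCC(Cn3ccnc3)C2)c(Cl)c1` gives 79 nM. Compound 2 stands at the high end of the three numbers: its gap to compound 3 is within the scatter, so no order between these two can be read, while its gap to compound 1 lies beyond the scatter, and compound 1 sits at the low end.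

Compound 4 `COc1cc([N+](=O)[O-])ccc1S(=O)(=O)N1CCCC(Cn2ccnc2)C1` is not yet measured in this assay. It differs from compound 2 in one place: nitro in place of methoxy on an aromatic carbon. Within the data shown here, no step between measured compounds isolates this change, so the expectation rests on the three numbers alone. Compound 3, which also carries a group other than methoxy in this region, gives 79 nM, and compound 1 gives 14 nM, so a downward step from compound 2 of moderate size, near the edge of the scatter, is expected. The estimate is a step of a 2.2-fold lower number from compound 2 to compound 4 (0.34 log units; beyond the scatter) from compound 2 to compound 4. Compound 4 is expected at 60 nM, within a range from 15 nM to 250 nM.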

Compound 4, half-maximal inhibitory concentration: 129 nM
For compound 4 the middle estimate is 2.2-fold (0.33 log units) below the measured one; the range from low to high includes it.
By their numbers in this assay, from the lowest: compound 1; then compounds 3, 4 and 2 (each within the scatter of the next).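

Nitro in place of methoxy on this aromatic carbon, para to a large group, gives a 1.0-fold lower number from compound 2 to compound 4 (0.01 log units; within the scatter) in this assay and thus isolates a single change at this position for the first time. The earlier compounds shown here offered no such step. With the methoxy group meta to this carbon kept in place, the two groups cannot be told apart here, although they differ in heavy atoms and hydrogen-bond acceptors. No measured property of either group is available to bear on this result.

On these data alone, whether this position responds to other kinds of group remains open: an amine, a carboxylic acid or a longer chain such as ethoxy on the same carbon would test this. Also open, as far as these compounds go, is whether nitro and methoxy would still match without the second methoxy group.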